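The source may report more compounds than this note shows. Statements on the series, on what has been measured and on what is new or still open speak of the compounds shown alone.

Working notes on the series in a functional assay on NCI-H460 cells (Homo sapiens) for cytotoxicity, read by MTT assay, with a stated time of 3 days; a lower number here means a stronger inhibitor, a higher number a weaker inhibitor: compound 1 `N#Cc1c(O)nc(SCc2nc3ccccc3[nH]2)nc1-c1ccccc1` gives 2.5 nM, compound 2 `N#Cc1c(NN)nc(SCc2nc3ccccc3[nH]2)nc1-c1ccccc1` gives 2.6 nM, and compound 3 `CCNc1nc(SCc2nc3ccccc3[nH]2)nc(-c2ccccc2)c1C#N` gives 2.87 nM, which places compound 3 level with both others within the scatter. Compound 4 `N#Cc1c(NC(N)=S)nc(SCc2nc3ccccc3[nH]2)nc1-c1ccccc1` differs from compound 3 on a nitrogen on an aromatic ring: a group of 3 heavy atoms (1 carbon, 1 nitrogen, 1 sulfur; no ring) in place of a group of 2 heavy atoms (2 carbon; no ring), on a nitrogen on an aromatic ring. The measured steps at this place are a 1.0-fold higher number from compound 1 to compound 2 (0.02 log units; within the scatter), a 1.1-fold higher number from compound 1 to compound 3 (0.06 log units; within the scatter) and a 1.1-fold higher number from compound 2 to compound 3 (0.04 log units; within the scatter), all small. Among the measured compounds shown here, none of the measured compounds carries the entering group, so this rests on analogy alone. No change beyond the scatter is expected in this assay, and the expected size is a 1.0-fold higher number from compound 3 to compound 4 (0.02 log units; within the scatter). For compound 4 the estimate is 3 nM, with an expected range of 1.5 nM to 6.5 nM.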

Compound 4, half-maximal inhibitory concentration: 3.37 nM
Compound 4: the middle estimate sits 1.1-fold (0.05 log units) below what was measured; low and high end bracket the measured number.
By their numbers in this assay, from the lowest: compounds 1, 2, 3 and 4 (each within the scatter of the next).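

At the nitrogen on an aromatic ring in this assay, the entering group, with its 1 sulfur and 1 double bond outside aromatic rings, stays level with ethyl (a 1.2-fold higher number from compound 3 to compound 4 (0.07 log units; within the scatter)). It also stays level with the two earlier groups (a 1.3-fold higher number from compound 2 to compound 4 (0.11 log units; within the scatter); a 1.3-fold higher number from compound 1 to compound 4 (0.13 log units; within the scatter)), so all four compounds remain within the scatter of one another at this place. Nothing measured here bears on why these steps stay small.

On these data alone, whether a longer chain, a carboxylic acid or a cyclic amine at this place would move the number beyond the scatter remains open, as does the effect of any change elsewhere on the shared core.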